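Aryl substitution on the sulfonamide nitrogen: expectation for compound 4

The source may hold more compounds than are shown below. What is called first, only, known or untested is meant among the compounds shown, and "the series" means these compounds.

Compound 1 `CC1(C)C=C(n2ccccc2=O)c2cc(S(N)(=O)=O)ccc2O1` carries an unsubstituted sulfonamide nitrogen. In a functional assay on the whole organism (aorta) with Rattus norvegicus as the target (on this read-out higher numbers stand for larger maximal responses and lower numbers for smaller maximal responses), compound 1 gives 77.5%, the highest of the two single numbers in the set, though the gap to compound 2 lies within the scatter. Compound 2 `CC1(C)C=C(n2ccccc2=O)c2cc(S(=O)(=O)NCc3ccccc3)ccc2O1` has benzyl in place of hydrogen on that nitrogen; in this assay compound 2 gives 71.1%, and the step is a number 6.4 percentage points lower from compound 1 to compound 2 (within the scatter). Compound 3 `CC1(C)C=C(n2ccccc2=O)c2cc(S(=O)(=O)Nc3ccccc3)ccc2O1` has phenyl there and was measured twice in this assay, compound 3 giving 63.6%; 82.5% (2 entries); the spread between the two entries the several entries of compound 3 in this assay, 63.6%; 82.5% (2 entries) is as wide as any difference seen in the set, and they bracket the number of compound 1.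

Compound 4 `CC1(C)C=C(n2ccccc2=O)c2cc(S(=O)(=O)Nc3ccc(C#N)cc3)ccc2O1` differs from compound 1 by 4-cyanophenyl in place of hydrogen on a sulfonamide nitrogen. Within the data shown here, the one single-place step measured, from compound 1 to compound 2, stayed within the scatter, and the duplicate of compound 3 shows no clear shift for phenyl either. No step beyond the scatter is therefore expected for compound 4, the expected step being a number 5.5 percentage points lower from compound 1 to compound 4 (within the scatter). Compound 4 is estimated at 72%, within a range of 58% to 86% that reflects the wide duplicate of compound 3.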

Compound 4, largest response reached (Emax), in percent of the reference or control that the assay uses: 84%
Compound 4: middle estimate off by 12 percentage points, on the low side; the measured number falls inside the stated range.
By their numbers in this assay, from the lowest: compounds 2, 1 and 4 (each within the scatter of the next, the first and the last beyond it).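

Hydrogen and 4-cyanophenyl on the sulfonamide nitrogen are not told apart in this assay, the step being a number 6.5 percentage points higher from compound 1 to compound 4 (within the scatter). Among these compounds, the exchange of benzyl for 4-cyanophenyl gives the first step in the set beyond the scatter, a number 12.9 percentage points higher from compound 2 to compound 4 (beyond the scatter), so this position does separate two of its substituents, if only modestly. That step is smaller than the gap between the repeat entries of compound 3, so it is held loosely because of the spread in those entries: the several entries of compound 3 in this assay, 63.6%; 82.5% (2 entries).

As far as these compounds go, whether the nitrile adds anything to the phenyl ring stays open, with no firm number for compound 3 to set against compound 4. Also open, from the compounds shown here alone, is how a phenyl ring carrying a carboxylic acid or an amine in place of the nitrile, or a longer alkyl chain on the nitrogen, would read in this assay.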